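The compounds below may be only part of what the source reports. "The series", "measured", "known", "first", "only" and "open" are said of these compounds alone.

Measured in a functional assay on KB cells (Homo sapiens) for cytotoxicity, read by MTT assay, with a stated time of 72 h; a higher number here means that more compound is needed for the effect, a lower number that less compound is needed:

- compound 1, `COc1ccc(/C=C2\C(=O)N(c3c(Cl)cccc3Cl)c3ccccc32)cc1OC`, gives 10 ug/mL
- compound 2, `O=C1/C(=C\c2ccc(F)cc2)c2ccccc2N1c1c(Cl)cccc1Cl`, gives 5 ug/mL
- compound 3, `Cc1ccc2nc(Cl)c(/C=C3\C(=O)N(c4c(Cl)cccc4Cl)c4ccccc43)cc2c1C`, gives 10 ug/mL

Compound 2 gives the smallest number of the three, but its gaps to compound 1 and to compound 3 are both within the usual scatter of this assay, so the three compounds cannot be told apart on these numbers. All three share the same core and differ only in the ring carried on the double-bonded chain carbon.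

Compound 4, `O=C1/C(=C\c2cccc(Br)c2)c2ccccc2N1c1c(Cl)cccc1Cl`, has not yet been measured. It differs from compound 2 by 3-bromophenyl in place of 4-fluorophenyl on a double-bonded chain carbon bound to a double-bonded ring carbon. Within the data shown here, no pair of measured compounds shows what such a swap does, and the three measured rings, which differ more widely among themselves, all give numbers within the scatter of one another. On that basis the step from compound 2 to compound 4 is expected to be a 1.2-fold higher number from compound 2 to compound 4 (0.08 log units; within the scatter), that is, nothing beyond the scatter. Compound 4 is therefore estimated at 6 ug/mL in this assay, with a range from 2.5 ug/mL to 15 ug/mL.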

Compound 4, concentration for half-maximal effect: 2 ug/mL
Compound 4: the middle estimate sits 3.0-fold (0.48 log units) above what was measured; the measured number lies below the stated range.
By their numbers in this assay, from the lowest: compound 4; then compounds 2, 1 and 3 (each within the scatter of the next).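

In this assay, among these compounds, the swap gives a 2.5-fold lower number from compound 2 to compound 4 (0.40 log units; beyond the scatter) and is the first change on this double-bonded chain carbon that can be read beyond the scatter, so the ring held here can affect the number, if only modestly on this single pair. The swap changes both the halogen and where it sits on the phenyl ring, and this one pair cannot separate those two changes. Nothing shown explains the lower number.

A 3-fluorophenyl or a 4-bromophenyl group would help separate the effect of the halogen from that of its place on the ring. As far as these compounds go, it also remains open whether a phenyl ring carrying an amine or a carboxylic acid here would lower the number further, leave it unchanged or raise it.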